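The compounds below may be only part of what the source reports. "The series", "measured", "known", "first", "only" and "open" are said of these compounds alone.

Compound 1 (`CCC(CC)O[C@@H]1C=C(C(=O)O)C[C@H](NCc2ccc(C(C)(C)C)cc2)[C@H]1NC(C)=O`) and compound 2 (`CCC(CC)O[C@@H]1C=C(C(=O)O)C[C@H](NCc2ccc(OC)cc2)[C@H]1NC(C)=O`) share a core and differ in one group, and both were tested in an ADME assay on cells (Fibroblast, Gallus gallus) for cytotoxicity, read by CCK-8 assay, with a stated time of 48 h; on this read-out lower numbers stand for higher toxicity in this test and higher numbers for lower toxicity in this test. Compound 1 gives > 200000 nM, which is a limit of the assay and not a number. Compound 2 gives > 200000 nM, which is also a limit. Compound 2 therefore stands with the only other result shown, at the limit of > 200000 nM in this assay, at which 2 of the 2 values shown sit. For the measured compounds named here, the one measured step is a step that the two limits leave unreadable from compound 1 to compound 2, where methoxy takes the place of tert-butyl on an aromatic carbon, and it offers no size to carry forward.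

Compound 3 (`CCC(CC)O[C@@H]1C=C(C(=O)O)C[C@H](NCc2ccc(OC(C)C)cc2)[C@H]1NC(C)=O`) has not yet been measured. It differs from compound 2 by isopropyl in place of methyl on an oxygen on an aromatic ring, turning 4-methoxyphenyl into 4-isopropoxyphenyl. No step beyond the usual scatter is expected in this assay, in either direction, since compound 1 and compound 2 both sit at the limit of > 200000 nM in this assay, at which 2 of the 2 values shown sit. Most likely the assay will again report only a limit. The estimated step is a number no higher from compound 2 to compound 3 (the limit leaves the size open). For compound 3 the expected value is 200000 nM, with an estimated range from 100000 nM to 400000 nM.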

Compound 3, half-maximal cytotoxic concentration: > 200000 nM
Compound 3: no number, only a limit; the forecaster's own chance of this, stated with the estimate: 90%; the middle value sits exactly at the limit.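

In this assay compound 3 gives > 200000 nM, which is a limit and not a number. No size can therefore be read for the steps from compound 1 or compound 2 to compound 3, as all three compounds share one limit: the limit of > 200000 nM in this assay, at which 3 of the 3 values shown sit.

The compounds shown leave open whether these groups differ at all in their toxicity to the cells.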